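Thiourea to urea on a Bcl-2 sulfonylpiperazine pair

The source may hold more compounds than are shown below. What is called first, only, known or untested is meant among the compounds shown, and "the series" means these compounds.

Compound 1: `COc1ccc(Oc2ccccc2-c2ccsc2S(=O)(=O)N2CCN(C(=O)Nc3ccc([N+](=O)[O-])cc3)CC2)cc1OC` gives 17%
Compound 2: `COc1ccc(Oc2ccc([N+](=O)[O-])cc2-c2ccsc2S(=O)(=O)N2CCN(C(=S)Nc3ccc([N+](=O)[O-])cc3)CC2)cc1OC` gives 16%

Of the compounds shown here, two have been measured in an assay for binding affinity to Apoptosis regulator Bcl-2 (Homo sapiens), read by fluorescence polarization, with stated times of 30 min and 20 min, tested at 100 uM; a lower number here means less inhibition, a higher number more inhibition at the concentration tested (going by the name of the read-out). Compound 1 reaches 17% and compound 2 reaches 16%. On the numbers shown, compound 2 gives the smaller of the two, though compound 1 differs from it by an amount that lies within the usual scatter, so the two cannot be told apart.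

Compound 3, `COc1ccc(Oc2ccc([N+](=O)[O-])cc2-c2ccsc2S(=O)(=O)N2CCN(C(=O)Nc3ccc([N+](=O)[O-])cc3)CC2)cc1OC`, is not yet measured. It differs from compound 2 in one place: a group of 12 heavy atoms (7 carbon, 2 nitrogen, 3 oxygen; one six-membered aromatic ring of carbon only) in place of a group of 12 heavy atoms (7 carbon, 2 nitrogen, 2 oxygen, 1 sulfur; one six-membered aromatic ring of carbon only), on an amine nitrogen in a ring

Among the measured compounds shown here, no step between measured compounds is known here, so the size of this change has no direct precedent. Compound 1 shares the carbamoyl group that enters and gives 17%, which sits beside the number for compound 2. Compound 3 is therefore expected to show no step beyond the scatter, with a number 1 percentage points higher from compound 2 to compound 3 (within the scatter) in this assay. The estimate for compound 3 is 17%, within a range from 5% to 30%.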

Compound 3, a percentage reported as inhibition, at one concentration (the size of the read-out at that concentration, not a potency): 19%
For compound 3 the middle estimate is 2 percentage points below the measured one; the measured number falls inside the stated range.
By their numbers in this assay, from the lowest: compounds 2, 1 and 3 (each within the scatter of the next).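

In this assay, placing (4-nitrophenyl)carbamoyl on the amine nitrogen in the ring, in place of the sulfur-bearing group of the same size, gives a number 3 percentage points higher from compound 2 to compound 3 (within the scatter) and so leaves the read-out indistinguishable across this exchange of one oxygen for one sulfur. Among the compounds shown here, this is the first direct comparison at this position, and it shows that with the donor and acceptor counts unchanged, the swap produces no step that can be separated from the scatter. The second change, nitro in place of hydrogen on an aromatic carbon, gives a number 2 percentage points higher from compound 1 to compound 3 (within the scatter) and likewise cannot be told from no change, while no supporting information is available that would account for either step.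

As far as these compounds go, what remains open is whether any change at these two places can move the read-out beyond the scatter, for example an amine or a carboxylic acid in place of the nitro on the (4-nitrophenyl)carbamoyl group, or a longer chain between its carbonyl and its aromatic ring. The single-concentration percentages shown also leave open how these compounds would compare as full potencies.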